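Swapping the Piperazine for Piperidine in a Weak Series

The source may hold more compounds than are shown below. What is called first, only, known or untested is meant among the compounds shown, and "the series" means these compounds.

Of the compounds shown here, three sharing one core have been measured in a functional assay on HeLa cells (Homo sapiens) for inhibition, read by MTT assay, with a stated time of 48 h; a lower number here means a stronger inhibitor, a higher number a weaker inhibitor. Compound 1 `CN1CCN(c2ccc(Nc3ncc4c(n3)N(C3CCCC3)CC(=O)N4)nc2)CC1` gives > 30000 nM, which is a limit of this assay and not a number. Compound 2 `O=C1CN(C2CCCC2)c2nc(Nc3ccc(N4CCCCC4)cn3)ncc2N1` likewise gives > 30000 nM, again a limit of this assay. Compound 3 `CCN1C(=O)CN(C2CCCC2)c2nc(Nc3ccc(N4CCN(C)CC4)cn3)ncc21` is the only one of the three that yields a number, 29100 nM. Compound 2 differs from compound 1 by piperidin-1-yl in place of 4-methylpiperazin-1-yl on an aromatic carbon, and the step that the two limits leave unreadable from compound 1 to compound 2 is lost between two limits. Compound 3 differs from compound 1 by ethyl in place of hydrogen on an amide-type nitrogen in a ring, and the step of an at least 1.0-fold lower number from compound 1 to compound 3 (0.01 log units; that floor lies within the scatter) says nothing beyond scatter. With two of the three values at the limit of > 30000 nM in this assay, at which 2 of the 3 values shown sit, the set reads as uniformly weak.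

Compound 4 `CCN1C(=O)CN(C2CCCC2)c2nc(Nc3ccc(N4CCCCC4)cn3)ncc21` has not yet been measured in this assay. It differs from compound 3 by piperidin-1-yl in place of 4-methylpiperazin-1-yl on an aromatic carbon. Going by the values given here, this is the same change as the one made from compound 1 to compound 2, now carried out on the core of compound 3, and the two cores differ by ethyl in place of hydrogen on an amide-type nitrogen in a ring. The earlier step that the two limits leave unreadable from compound 1 to compound 2 gives no readable size, and compound 3 gives 29100 nM, a weak number. Compound 4 is therefore expected at 40000 nM, between 15000 nM and 120000 nM, a step of a 1.4-fold higher number from compound 3 to compound 4 (0.14 log units; within the scatter), most likely reported only as a limit.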

Compound 4, half-maximal inhibitory concentration: 17600 nM
For compound 4 the middle estimate is 2.3-fold (0.36 log units) above the measured one; low and high end bracket the measured number.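

On the core of compound 3, piperidin-1-yl in place of 4-methylpiperazin-1-yl gives a 1.7-fold lower number from compound 3 to compound 4 (0.22 log units; within the scatter) in this assay, so on this core the exchange does not separate the two compounds beyond the scatter. The same exchange on the core of compound 1 cannot be read, so it has a readable size on one core only, and the compounds shown do not tell whether it carries over from one core to the other. The other change, ethyl in place of hydrogen on the amide-type nitrogen in the ring, gives an at least 1.7-fold lower number from compound 2 to compound 4 (0.23 log units; that floor lies within the scatter), and this can be set beside the same change on the core of compound 1, though without a firm comparison: the same change on two cores in this assay, an at least 1.0-fold lower number (0.01 log units; that floor lies within the scatter) from compound 1 to compound 3 and an at least 1.7-fold lower number (0.23 log units; that floor lies within the scatter) from compound 2 to compound 4; the limit leaves it open whether they differ.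

The compounds shown leave open whether another group on this aromatic carbon, such as morpholin-4-yl or a primary amine, would give a number clearly apart from those of compound 3 and compound 4. They also leave open whether a longer chain than ethyl on the amide-type nitrogen would do so, and the series offers few numbers to judge this by: the limit of > 30000 nM in this assay, at which 2 of the 4 values shown sit.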